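The compounds below may be only part of what the source reports. "The series", "measured", "known", "first", "only" and "open" are said of these compounds alone.

Measured in an ADME assay on THP-1 cells (Homo sapiens) for cytotoxicity, read by MTT assay, with a stated time of 72 h; on this read-out higher numbers stand for lower toxicity in this test and lower numbers for higher toxicity in this test:
- compound 1 `C=C(C(=O)OCC)C(O)c1ccc(Cl)cc1Cl`: 68.3 uM
- compound 2 `C=C(C(=O)O)C(O)c1ccccc1Cl`: > 100 uM (a limit)
- compound 3 `C=C(C(=O)OCC)C(OCCC(=O)OCC)c1ccccc1Cl`: > 100 uM (a limit)

Compound 3 stands at a limit of this assay, not at a number: > 100 uM. Compound 2 sits at the same limit. Compound 4 `C=C(C(=O)OCC)C(OCCC(=O)OCC)c1ccc(Cl)cc1Cl` has chloro in place of hydrogen on an aromatic carbon of compound 3, taking 2-chlorophenyl to 2,4-dichlorophenyl: chloro in place of hydrogen on an aromatic carbon. Going by the values given here, no measured pair isolates this change. Among the compounds with values here, compound 1, the only measured compound with 2,4-dichlorophenyl, gives 68.3 uM, the one actual number. On that basis, a modest shift towards higher toxicity is expected, and the estimated change is an at least 1.3-fold lower number from compound 3 to compound 4 (0.12 log units; that floor lies within the scatter). Compound 4 is estimated at 75 uM, with an expected range of 35 uM to 130 uM.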

Compound 4, half-maximal toxic concentration: > 100 uM
Compound 4: a limit, no number; the forecaster's own chance of this, stated with the estimate: 35%; at least 1.3-fold (0.12 log units) between middle value and limit.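

In this assay compound 4 gives a limit, not a number: > 100 uM. With 2,4-dichlorophenyl held fixed, 2-(ethoxycarbonyl)ethyl in place of hydrogen on the oxygen gives an at least 1.4-fold higher number from compound 1 to compound 4 (0.16 log units; that floor lies within the scatter). The step for chloro in place of hydrogen, para to a large group, cannot be read because both of its ends sit at one limit: the limit of > 100 uM in this assay, at which 3 of the 4 values shown sit.

From the compounds shown here alone, whether this chloro changes the read-out in the 2-(ethoxycarbonyl)ethyl compounds stays open, with no number on either side. Also open, going by these compounds, is how an amine or a longer chain in place of 2-(ethoxycarbonyl)ethyl would read in this assay.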